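From hydroxy to methoxy on compound 1

The source may report more compounds than this note shows. Statements on the series, on what has been measured and on what is new or still open speak of the compounds shown alone.

Compound 1 (`O=C(N/N=C1\C[C@@H](c2ccc(O)cc2)Oc2cc(O)cc(O)c21)c1ccco1`) was tested in a functional assay on L5178Y cells (Mus musculus) for inhibition, read by MTT assay, with a stated time of 24 h (a higher number here means a weaker inhibitor, a lower number a stronger inhibitor), and compound 1 gives >= 11300 nM as a limit, not a number. Compound 2 (`O=C(Cc1c[nH]c2ccccc12)N/N=C1\C[C@@H](c2ccc(O)cc2)Oc2cc(O)cc(O)c21`) gives >= 11300 nM as a limit too. Compound 3 (`CN(C)C(=S)N/N=C1\C[C@@H](c2ccc(O)cc2)Oc2cc(O)cc(O)c21`) likewise gives >= 11300 nM as a limit. Compound 1 therefore has no exact standing, and the three share one edge of this assay with no ranking among them.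

Compound 4 (`COc1cc(O)c2c(c1)O[C@H](c1ccc(O)cc1)C/C2=N\NC(=O)c1ccco1`) turns hydroxy to methoxy (methyl in place of hydrogen on an oxygen on an aromatic ring), with methyl in place of hydrogen on an oxygen on an aromatic ring. For the measured compounds named here, two measured steps bear on this only loosely: a step that the two limits leave unreadable from compound 1 to compound 2 and a step that the two limits leave unreadable from compound 1 to compound 3 both change another place, and neither has a readable size.

Because the limit of >= 11300 nM in this assay, at which 3 of the 3 values shown sit, applies to compound 1 and both its neighbours, no direction can be read from them. The expected step is a step that the limit leaves unreadable from compound 1 to compound 4 and it is not expected to exceed the scatter. Compound 4 is estimated at 12000 nM within a range of 6000 nM to 30000 nM, and a limit rather than a number is expected again.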

Compound 4, half-maximal inhibitory concentration: >= 11300 nM
Compound 4 ended at the assay's limit; the forecaster's own chance of this, stated with the estimate: 70%; the middle value lies beyond the limit too.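

Compound 4, like compound 1, ended at a limit and not at a number, so no step can be read between the two: the limit of >= 11300 nM in this assay, at which 4 of the 4 values shown sit.

The compounds shown leave open how strong any of them is as an inhibitor, and whether methyl in place of hydrogen on an oxygen on an aromatic ring changes that at all.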